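A few compounds are considered here, and "the series" means these few. Any claim that something is new, unique, unknown or untested is made for them only; others in the source may bear on it.

Measured compounds:
Compound 1, `CCc1ccc(Nc2nc3nonc3nc2O)cc1`: 10700 nM
Compound 2, `CCCCCc1ccc(Nc2nc3nonc3nc2O)cc1`: 2400 nM

Within an assay on mitochondria from L6 cells (Rattus norvegicus) for activation, with a stated time of 90 min (on this read-out higher numbers stand for an effect only at larger amounts of compound and lower numbers for an effect already at smaller amounts), compound 2 holds the lowest of the two numbers, and the only step in view, a 4.5-fold lower number from compound 1 to compound 2 (0.65 log units; beyond the scatter), separates it from compound 1. Compound 3, `Oc1nc2nonc2nc1Nc1ccc(OC(F)(F)C(F)F)cc1`, has not been measured in this assay. For the measured compounds named here, its change from compound 2 is 1,1,2,2-tetrafluoroethoxy in place of pentyl on an aromatic carbon; the pentyl chain whose growth from ethyl gave the single step in hand is exchanged for a group of 7 heavy atoms carrying one hydrogen-bond acceptor. That step, a 4.5-fold lower number from compound 1 to compound 2 (0.65 log units; beyond the scatter), bears on the present change only loosely, since the group that enters is neither the chain that leaves nor the shorter chain of compound 1. A modest rise in the number, a 1.7-fold higher number from compound 2 to compound 3 (0.22 log units; within the scatter), is therefore expected, with wide uncertainty. Compound 3 is estimated at 4000 nM, in the range 1500 nM to 12000 nM.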

Compound 3, half-maximal effective concentration: 7000 nM
For compound 3 the middle estimate is 1.8-fold (0.24 log units) below the measured one; measured number inside the range.
By their numbers in this assay, from the lowest: compound 2; then compounds 3 and 1 (each within the scatter of the next).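

In this assay, this aromatic carbon accepts a group carrying oxygen and fluorine as well as a saturated chain, yet 1,1,2,2-tetrafluoroethoxy in place of pentyl gives up ground (a 2.9-fold higher number from compound 2 to compound 3 (0.46 log units; beyond the scatter)). Set against the ethyl of compound 1, the same group cannot be told apart (a 1.5-fold lower number from compound 1 to compound 3 (0.18 log units; within the scatter)), so compound 2 alone stands clear of the other two, its steps to both lying beyond the scatter. No measurement at hand speaks to what lies behind these differences.

With only ethyl and pentyl as chains, the compounds shown leave open whether the number keeps falling with a longer chain such as heptyl. They also leave open how an amine or a carboxylic acid would read on this aromatic carbon.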